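Chloro in Place of Methyl on the Aryl Ketone

The compounds below may be only part of what the source reports. "The series", "measured", "known", "first", "only" and "open" are said of these compounds alone.

Measured compounds:
compound 1 `COc1ccc(-c2cc(/C=C/C(=O)c3ccc(C)cc3)nc3cc(-c4ccccc4)nn23)cc1OC`: 62600 nM
compound 2 `COc1cc(-c2cc(/C=C/C(=O)c3ccc(C)cc3)nc3cc(-c4ccccc4)nn23)cc(OC)c1OC`: 50400 nM

In an ADME assay on HEK293 cells (Homo sapiens) for antiproliferative activity, read by MTT assay, with a stated time of 24 h (a higher number here means a weaker inhibitor, a lower number a stronger inhibitor), compound 2 gives 50400 nM, and compound 1 gives 62600 nM. Going by the values given here, these two numbers stand within the scatter of each other: the single step between them, a 1.2-fold lower number from compound 1 to compound 2 (0.09 log units; within the scatter), adds a methoxy group on an aromatic carbon and does not separate the two compounds in this assay. Compound 2 therefore stands on a par with compound 1, with nothing yet measured that sets it apart.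

Compound 3 `COc1cc(-c2cc(/C=C/C(=O)c3ccc(Cl)cc3)nc3cc(-c4ccccc4)nn23)cc(OC)c1OC` differs from compound 2 by chloro in place of methyl on an aromatic carbon. Among the compounds with values here, no measured step concerns this exchange; the one step in hand, from compound 1 to compound 2, touches a methoxy on a different ring and offers no guidance on swapping a methyl for a chloro. With nothing pointing either way, the expectation for this assay is a step no larger than the scatter, a 1.0-fold lower number from compound 2 to compound 3 (0.00 log units; within the scatter). Compound 3 is accordingly estimated at 50000 nM, with a range from 20000 nM to 125000 nM that allows for the usual scatter and for the untested nature of the change.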

Compound 3, half-maximal inhibitory concentration: >= 100000 nM
Compound 3: only a limit was reported; the forecaster's own chance of this, stated with the estimate: 10%; at least 2.0-fold (0.30 log units) between middle value and limit.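

In this assay compound 3 gives >= 100000 nM, which is a limit of the assay and not a number. Going by these compounds alone, exchanging 4-methylphenyl for 4-chlorophenyl gives the first reading at this position, an at least 1.9-fold higher number from compound 2 to compound 3 (0.29 log units; that floor lies within the scatter); only a floor of the step is known, and because that floor lies within the scatter, the reading does not establish a separation between the two compounds, nor does it show them to be on a par. Unlike the methoxy step on a different ring, which stays within the scatter with both of its values measured, this exchange on the aryl ketone has an open upper end, and what can be said of it rests on a single limit: the limit of >= 100000 nM in this assay, at which 1 of the 3 values shown sits.

The compounds shown leave open how large the step from methyl to chloro really is, and whether the same exchange would read alike on the core of compound 1. They also leave open how a fluoro, an amine or a carboxylic acid in the same place on the aryl ketone would read in this assay.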